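The compounds below may be only part of what the source reports. "The series", "measured", "known", "first", "only" and "open" are said of these compounds alone.

Among the measured compounds shown here, compound 3, `Cn1c(-c2ccccc2)c(C#N)c2c(N)ncnc21`, stands second highest of the three numbers measured so far in an assay on isolated protein for inhibition of Leucine-rich repeat serine/threonine-protein kinase 2 (Homo sapiens), read by TR-FRET and LanthaScreen, with stated times of 50 min and 30 min, in the presence of a further agent that is not named here; on this read-out lower numbers stand for stronger inhibition and higher numbers for weaker inhibition: compound 3 gives 1260 nM, while compound 1, `CN(C)c1c(C#N)c2c(N)ncnc2n1C`, gives 4620 nM and compound 2, `C[C@@H]1CCCN1c1c(C#N)c2c(N)ncnc2n1C`, gives 15 nM. The step of a 3.7-fold lower number from compound 1 to compound 3 (0.56 log units; beyond the scatter) is modest, whereas the step of an 84-fold higher number from compound 2 to compound 3 (1.92 log units; beyond the scatter) is large, and the step of a 310-fold lower number from compound 1 to compound 2 (2.49 log units; beyond the scatter) is large as well.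

Compound 4, `C[C@H]1CCCN1c1c(C#N)c2c(N)ncnc2n1C`, differs from compound 3 by 2-methylpyrrolidin-1-yl in place of phenyl on an aromatic carbon. Compound 4 carries the same 2-methylpyrrolidin-1-yl group as compound 2 but with the opposite configuration at its one defined stereocentre. For the measured compounds named here, the step that bears most directly on this change is the reverse of an 84-fold higher number from compound 2 to compound 3 (1.92 log units; beyond the scatter), which was large; no measured pair shows how the configuration of that stereocentre alters the number, so the size of the gain is uncertain. Compound 4 is therefore expected to give a clearly lower number than compound 3 in this assay, a step of about an 11-fold lower number from compound 3 to compound 4 (1.02 log units; beyond the scatter), though possibly a smaller gain than compound 2 shows. The estimate for compound 4 in this assay is 120 nM, expected to lie between 20 nM and 1000 nM.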

Compound 4, half-maximal inhibitory concentration: 5660 nM
Estimate against measurement, compound 4: 47-fold (1.67 log units) below; the measured number lies above the stated range.
By their numbers in this assay, from the lowest: compound 2; then compound 3; then compounds 1 and 4 (each within the scatter of the next).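

In this assay, the 2-methylpyrrolidin-1-yl group on this aromatic carbon does not by itself confer a low number, since its configuration decides the outcome: the step is a 380-fold higher number from compound 2 to compound 4 (2.58 log units; beyond the scatter), which is large and exceeds every other step among the four compounds. Drawn S, the ring offers no measurable gain over dimethylamino, with a 1.2-fold higher number from compound 1 to compound 4 (0.09 log units; within the scatter), and it does worse than phenyl, with a 4.5-fold higher number from compound 3 to compound 4 (0.65 log units; beyond the scatter), so the order of phenyl and this ring depends on the stereocentre, as compound 2 lies on the other side of compound 3. The large gap between the two ring compounds can be assigned to the stereocentre alone because nothing else separates them: the fact that compounds 2 and 4 differ only in the configuration as drawn.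

The compounds shown leave open what the methyl group contributes in either configuration, a question that a plain pyrrolidin-1-yl ring at this carbon would address. They also leave open whether the preference for the R drawing would persist with a longer chain, such as ethyl, at the same ring carbon, or with a six-membered piperidin-1-yl ring carrying a methyl group.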